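Triazole side chain to cyclopropyl: cytotoxicity expectation

A few compounds are considered here, and "the series" means these few. Any claim that something is new, unique, unknown or untested is made for them only; others in the source may bear on it.

Compound 3 `COc1nc2ccc(Br)cc2cc1C(c1ccccc1)n1cc(CCCCCO)nn1` gives 1.08% in an ADME assay on HeLa cells (Homo sapiens) for cytotoxicity, read by sulforhodamine B assay, with a stated time of 48 h, tested at 10 uM; on this read-out higher numbers stand for more inhibition at the one concentration tested (going by the name of the read-out) and lower numbers for less inhibition. The other two members sit alongside it: compound 1 `CCCCc1cn(C(c2ccccc2)c2cc3cc(Br)ccc3nc2OC)nn1` gives -2.87% and compound 2 `CCCCCCCCc1cn(C(c2ccccc2)c2cc3cc(Br)ccc3nc2OC)nn1` gives 0.1%, so all three numbers lie within the scatter of one another, compound 2 being the nearest to compound 3. The measured steps were a number 3 percentage points higher from compound 1 to compound 2 (within the scatter), a number 4 percentage points higher from compound 1 to compound 3 (within the scatter) and a number 1 percentage points higher from compound 2 to compound 3 (within the scatter), each within the scatter. Compound 4 `COc1nc2ccc(Br)cc2cc1C(c1ccccc1)n1cc(C2CC2)nn1` differs from compound 3 by cyclopropyl in place of 5-hydroxypentyl on an aromatic carbon. Among the measured compounds shown here, no measured step exchanges a chain for a ring, and the three available steps all left the read-out within the scatter. For compound 4 the expected step is therefore a number 1.1 percentage points lower from compound 3 to compound 4 (within the scatter), none beyond the scatter. Compound 4 is estimated at 0%, within -10% to 10%.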

Compound 4, a percentage reported as inhibition, at one concentration (the size of the read-out at that concentration, not a potency): -5.84%
Compound 4: middle estimate off by 5.8 percentage points, on the high side; the range from low to high includes it.
By their numbers in this assay, from the lowest: compounds 4, 1, 2 and 3 (each within the scatter of the next).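

In this assay this aromatic carbon carries a ring as readily as a chain, with cyclopropyl giving a number 6.9 percentage points lower from compound 3 to compound 4 (within the scatter) and a number 5.9 percentage points lower from compound 2 to compound 4 (within the scatter) and a number 3 percentage points lower from compound 1 to compound 4 (within the scatter). Replacing 5-hydroxypentyl with cyclopropyl also removes the hydrogen-bond donor and acceptor, and the step still stays within the scatter. No supporting data bear on this result.

On these data alone, whether an amine or a carboxylic acid at this position would take the read-out beyond the scatter remains open. The same question stands for a phenyl ring there.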